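A few compounds are considered here, and "the series" means these few. Any claim that something is new, unique, unknown or untested is made for them only; others in the source may bear on it.

Compound 1 `CC(C)N1CC(=O)N=C1N/C(=N\C(=O)C(C)(C)C)Nc1ccc(Cl)c(Cl)c1` is followed in an in vivo ADME assay on the whole organism for metabolic stability, with Mus musculus as the target, read by LC-MS, at a dose of 160 mg/kg by the oral route; a higher number here means that the compound lasts longer, a lower number that the compound disappears faster. In this assay compound 1 gives > 1 h, which is a limit of the assay and not a number. Compound 2 `CN1CC(=O)N=C1NC(=N)Nc1ccc(Cl)c(Cl)c1` gives > 1 h in this assay, again only a limit. Within the data shown here, the series so far rests on (the limit of > 1 h in this assay, at which 2 of the 2 values shown sit), so no measured step sets a size. Compound 3 `CC(C)N1CC(=O)N=C1N/C(=N\C(C)(C)C)Nc1ccc(Cl)c(Cl)c1` is not yet measured and differs from compound 1 by tert-butyl in place of (tert-butyl)carbonyl on a double-bonded nitrogen. Among the measured compounds shown here, with no measured step to draw on, the expected step is a step that the limit leaves unreadable from compound 1 to compound 3, within the scatter. Compound 3 is therefore estimated at 2 h, with a range from 0.7 h to 6 h.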

Compound 3, half-life: 0.0287 h
For compound 3 the middle estimate is 70-fold (1.84 log units) above the measured one; the whole stated range lies above it.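

In this assay, among these compounds, tert-butyl in place of (tert-butyl)carbonyl on a double-bonded nitrogen gives an at least 34-fold lower number from compound 1 to compound 3 (1.54 log units; beyond the scatter), the only readable step and evidence that this position can carry a large change. Compound 1 gives > 1 h, which is a limit of the assay and not a number. The full size of the step therefore stays unread, because one end of it is a limit: the limit of > 1 h in this assay, at which 2 of the 3 values shown sit.

The compounds shown do not separate the carbonyl from the rest of the leaving group. On these data alone, how acetyl or a longer acyl chain on that nitrogen would behave remains open.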